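This account rests on a few compounds, and the source may have more. Where it says the series, first, only, none or still open, it means among the compounds named here.

Compounds measured so far:
- Compound 1 `CC(C)C(C(=O)NC(N)=O)C(C)C`: 33 mg/kg
- Compound 2 `CCC[C@H](C(=O)NC(N)=O)C(C)C`: 18 mg/kg
- Compound 3 `CCCC(C(=O)NC(N)=O)C(C)C`: 16 mg/kg

In a functional assay on the whole organism (strain Sprague-Dawley) with Rattus norvegicus as the target, in the maximal electroshock model (on this read-out higher numbers stand for an effect only at larger amounts of compound and lower numbers for an effect already at smaller amounts), compound 3 gives 16 mg/kg, the lowest number of the three, although it stands within the scatter of compound 2. Its gap to compound 1 is larger: a 2.1-fold lower number from compound 1 to compound 3 (0.31 log units; beyond the scatter).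

Compound 4 `CCC[C@@H](C(=O)NC(N)=O)C(C)C` differs only in configuration: the two compounds have the same atoms and bonds; at least one stereo element is drawn with a configuration in one of them and without one in the other: 1 of 1 stereo elements differ; a stereocentre at a saturated chain carbon is drawn without a configuration in compound 3 and R in compound 4. The change of propyl for isopropyl does not bear on this. The relevant precedent is the same stereocentre drawn S, and that step is small: a 1.1-fold lower number from compound 2 to compound 3 (0.05 log units; within the scatter). Defining the configuration as S therefore moved the number by no more than the scatter. No step beyond the scatter is expected in this assay, and the expected step is a 1.1-fold lower number from compound 3 to compound 4 (0.03 log units; within the scatter). Compound 4 is estimated at 15 mg/kg, within a range of 9 mg/kg to 26 mg/kg.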

Compound 4, dose for half-maximal effect: 36 mg/kg
Beside the measured number, compound 4's estimate is 2.4-fold (0.38 log units) below it; the whole stated range lies below it.
By their numbers in this assay, from the lowest: compounds 3, 2, 1 and 4 (each within the scatter of the next, the first and the last beyond it).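

In this assay the stereocentre at this saturated chain carbon now gives a step beyond the scatter, though a modest one (a 2.3-fold higher number from compound 3 to compound 4 (0.35 log units; beyond the scatter)). Drawing it S had not done so, while drawing it R does, and configuration is the only difference in this step: the fact that one of compounds 3 and 4 is drawn with a defined configuration and the other without, at the place where they differ. The direct comparison of the two drawn configurations stays within the scatter (a 2.0-fold higher number from compound 2 to compound 4 (0.30 log units; within the scatter)), so compounds 2 and 4 cannot be ranked. From the compounds shown here alone, it remains open whether a longer chain such as pentyl in place of propyl would show the same dependence on configuration.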